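Swapping the alkyne substituent: from aryl back to alkyl

The compounds below may be only part of what the source reports. "The series", "measured", "known", "first", "only" and "open" are said of these compounds alone.

Compound 1 `CCCCCCCCC#Cc1cn(C/C=C\CN2C(=O)c3ccccc3C2=O)c(=O)[nH]c1=O`: 39000 nM in a functional assay on CCRF-CEM cells (Homo sapiens) for antiproliferative activity, read by MTT assay, with a stated time of 3 days; a higher number here means a weaker inhibitor, a lower number a stronger inhibitor
Compound 2 `O=C1c2ccccc2C(=O)N1C/C=C\Cn1cc(C#Cc2ccc(Br)cc2)c(=O)[nH]c1=O`: 80000 nM in this assay

For the measured compounds named here, compound 2 stands with the higher of the two numbers so far in this assay, and compound 1 is its only neighbour. Going by the values given here, the single measured step, a 2.1-fold higher number from compound 1 to compound 2 (0.31 log units; beyond the scatter), is modest but beyond the scatter. Compound 3 `CCCCC#Cc1cn(C/C=C\CN2C(=O)c3ccccc3C2=O)c(=O)[nH]c1=O` has not yet been measured; it differs from compound 2 by butyl in place of 4-bromophenyl on a triple-bonded carbon. Among the compounds with values here, this change runs in the opposite sense to the measured step, putting an alkyl chain back on the triple-bonded carbon in place of the aryl group, though the chain is shorter than the one in compound 1. The measured step is therefore expected to reverse in part, giving a modest drop of a 1.6-fold lower number from compound 2 to compound 3 (0.20 log units; within the scatter) for compound 3. On that basis compound 3 is estimated at 50000 nM in this assay, with a range from 20000 nM to 130000 nM.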

Compound 3, half-maximal inhibitory concentration: 100000 nM
The estimate for compound 3 lay 2.0-fold (0.30 log units) below the measured number, and the stated range covers the measured number.
By their numbers in this assay, from the lowest: compound 1; then compounds 2 and 3 (each within the scatter of the next).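

Putting butyl on the triple-bonded carbon in place of 4-bromophenyl gives a 1.3-fold higher number from compound 2 to compound 3 (0.10 log units; within the scatter) in this assay, so these two groups are not told apart at this position. Shortening the alkyl chain, by contrast, gives a 2.6-fold higher number from compound 1 to compound 3 (0.41 log units; beyond the scatter), a modest step but one beyond the scatter. An alkyl chain at this position therefore does not by itself give the lower number: among these three compounds, only compound 1, with its octyl chain, stands apart. Nothing available here accounts for these differences.

Whether a chain longer than octyl would lower the number further remains open, since only two chain lengths are shown. So does the effect of a hydroxyl or an amine at the end of the chain.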